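Replacing the Benzoyl Group by a Nitrile on a Shared Core

The source may report more compounds than this note shows. Statements on the series, on what has been measured and on what is new or still open speak of the compounds shown alone.

Compound 1, `COc1ccc(C(=O)c2ccc3c(c2)C(n2ccccc2=O)=CC(C)(C)O3)cc1`: 5.72
Compound 2, `CC1(C)C=C(n2ccccc2=O)c2cc(C(=O)c3ccccc3F)ccc2O1`: 6.34
Compound 3, `CC1(C)C=C(n2ccccc2=O)c2cc(C(=O)c3c(F)cccc3F)ccc2O1`: 5.99

In a functional assay (trachea) with Rattus norvegicus as the target (on this read-out higher numbers stand for higher potency (the scale is a negative logarithm) and lower numbers for lower potency), compound 2 stands highest of the three: the nearest value belongs to compound 3, with a number 0.35 log units lower from compound 2 to compound 3 (beyond the scatter), and the furthest to compound 1, with a number 0.62 log units higher from compound 1 to compound 2 (beyond the scatter) running up to compound 2. Compound 4, `CC1(C)C=C(n2ccccc2=O)c2cc(C#N)ccc2O1`, changes the core elsewhere: cyano in place of (2-fluorophenyl)carbonyl on an aromatic carbon. For the measured compounds named here, no measured step covers this exchange; the known steps, including a number 0.27 log units higher from compound 1 to compound 3 (within the scatter), vary only the aryl ring on the carbonyl and stay modest. With the whole carbonyl-bearing group leaving, the direction is open, so the expected step is a number 0.06 log units higher from compound 2 to compound 4 (within the scatter), held near zero with a wide spread. Compound 4 is therefore estimated at 6.4, ranging from 5.6 to 7.2.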

Compound 4, logarithm of the reciprocal of the active concentration, log(1/C): 7.1
Compound 4: middle estimate off by 0.70 log units, on the low side; measured number inside the range.
By their numbers in this assay, from the lowest: compounds 1 and 3 (each within the scatter of the next); then compound 2; then compound 4.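

The (2-fluorophenyl)carbonyl group is not needed for activity at this aromatic carbon of the shared core: exchanging it for cyano gives a number 0.76 log units higher from compound 2 to compound 4 (beyond the scatter). The earlier compounds shown here changed only the aryl ring on the carbonyl, whereas this step shows that a much smaller group with no ring can take this place. No measurement shown here explains the step.

The compounds shown cannot separate a contribution of the nitrile from the loss of the aryl carbonyl. As far as these compounds go, how a simple hydrogen, a carboxylic acid or an amine would read at this carbon remains open.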